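Oxan-4-yl for Methyl on a Fused Aromatic Nitrogen

The source may report more compounds than this note shows. Statements on the series, on what has been measured and on what is new or still open speak of the compounds shown alone.

Measured compounds:
- Compound 1, `CN(C)[C@H]1CC[C@H](Nc2ncnc3cscc23)CC1`: 0.3
- Compound 2, `CN(C)[C@H]1CC[C@H](Oc2ncnn3ccc([C@H]4CC[C@H](C(N)=O)CC4)c23)CC1`: 1
- Compound 3, `Cn1ccc2ncnc(N[C@H]3CC[C@H](N(C)C)CC3)c21`: -0.8

All three compounds share a dimethylamino-cyclohexyl group joined to a fused two-ring aromatic system. In a physicochemical assay for lipophilicity, using the shake flask method, at pH 7.4 (on this read-out higher numbers stand for higher lipophilicity and lower numbers for lower lipophilicity), compound 3 gives -0.8, the lowest of the three numbers. In this assay compound 1 gives 0.3, a value beyond the usual scatter above that of compound 3, and compound 2 gives 1, the highest of the three and furthest from compound 3. None of the three pairs differs in only one place, so no single change can be read off as a measured step.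

Compound 4, `CN(C)[C@H]1CC[C@H](Nc2ncnc3ccn(C4CCOCC4)c23)CC1`, has not yet been measured. It differs from compound 3 by oxan-4-yl in place of methyl on an aromatic nitrogen. In words: oxan-4-yl in place of methyl on an aromatic nitrogen. Going by the values given here, no measured pair shows this exact change, so the expectation rests on the size of the group that enters compared with the one that leaves.

Starting from compound 3 and its value of -0.8, the step to compound 4 in this assay is expected to be a number 1.00 log units higher from compound 3 to compound 4 (beyond the scatter), an increase beyond the scatter. For compound 4 the estimated value in this assay is 0.2, with a likely range from -0.4 to 0.8.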

Compound 4, distribution coefficient: -0.6
Compound 4: middle estimate off by 0.80 log units, on the high side, outside the stated range (below it).
By their numbers in this assay, from the lowest: compounds 3 and 4 (each within the scatter of the next); then compound 1; then compound 2.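

In this assay, going by these compounds alone, putting oxan-4-yl in place of methyl on an aromatic nitrogen of a five-membered aromatic ring gives a number 0.20 log units higher from compound 3 to compound 4 (within the scatter) and so provides the first reading of a change made in one place in this set. At this position, a group of 6 heavy atoms, carrying a six-membered non-aromatic ring and 1 hydrogen-bond acceptor, replaces a group of 1 heavy atom, yet the two compounds remain within the usual scatter of each other, so the heavy-atom count of the entering group does not by itself set the read-out here. No measured information available here explains why this pair behaves in this way.

A single pair cannot separate the contribution of the ring carbons from that of the ring oxygen, and a cyclohexyl group on the same nitrogen would put that question directly. As far as these compounds go, it also remains open whether a chain such as n-butyl, or a ring carrying an amine such as piperidin-4-yl, would likewise stay within the scatter of compound 3 at this position.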